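Three aryl-substituted quinazolinones and a fourth awaiting measurement

This account rests on a few compounds, and the source may have more. Where it says the series, first, only, none or still open, it means among the compounds named here.

Compound 1, `Cc1ccc2nc(-c3ccccc3F)[nH]c(=O)c2c1`, gives > 50000 nM in a functional assay on HCT-15 cells (Homo sapiens) for cytotoxicity, read by MTT assay, with a stated time of 2 days; on this read-out lower numbers stand for stronger inhibition and higher numbers for weaker inhibition; this is a limit of the assay.
Compound 2, `Cc1ccc2nc(-c3cccc(F)c3)[nH]c(=O)c2c1`, gives > 50000 nM in this assay; this is a limit.
Compound 3, `Cc1ccc2nc(-c3cccc(OC(F)(F)F)c3)[nH]c(=O)c2c1`, gives > 50000 nM in this assay; this is a limit.

The three measured compounds share one core and differ only in the group on the attached phenyl ring. Compound 1 and compound 2 have the same atoms joined differently; the difference between their two cores is not broken down here. From compound 2 to compound 3 the change is trifluoromethoxy in place of fluoro on an aromatic carbon, and the step is a step that the two limits leave unreadable from compound 2 to compound 3. All that can be said of the three rests on (the limit of > 50000 nM in this assay, at which 3 of the 3 values shown sit).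

Compound 4, `Cc1ccc2nc(-c3ccccc3OC(F)(F)F)[nH]c(=O)c2c1`, is not yet measured. It differs from compound 1 by trifluoromethoxy in place of fluoro on an aromatic carbon, the same kind of change as from compound 2 to compound 3, but here the place is ortho to a large group rather than meta to it. Since the measured step of this kind is unreadable, compound 4 is expected to behave like compound 1, with a step that the limit leaves unreadable from compound 1 to compound 4 in this assay. Compound 4 is therefore estimated at 80000 nM, most likely again only a limit, within 30000 nM to 250000 nM.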

Compound 4, half-maximal inhibitory concentration: 2790 nM
Compound 4: middle estimate off by 29-fold (1.46 log units), on the high side; measured number outside the range, below it.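

In this assay, trifluoromethoxy in place of fluoro on an aromatic carbon, ortho to a large group, gives an at least 17-fold lower number from compound 1 to compound 4 (1.25 log units; beyond the scatter), so in this one place the change has a large effect. As far as these compounds go, compound 1 is held only by a limit, so the true size of this step stays unknown beyond what is printed. The same change between compound 2 and compound 3 cannot be read, so the series does not show whether the effect carries from one core to the other, either as present or as absent, because both ends of that step sit at the limit: the limit of > 50000 nM in this assay, at which 3 of the 4 values shown sit.

The compounds shown leave open whether the lower number belongs to trifluoromethoxy itself or would also appear with another group in that place, such as an amine, a carboxylic acid or a longer chain. They also leave open whether compound 4, at 2790 nM, would keep its standing on any cell line other than the one used here.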